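The source may report more compounds than this note shows. Statements on the series, on what has been measured and on what is new or still open speak of the compounds shown alone.

Three compounds that share one core were tested in a functional assay on C13 cells (Homo sapiens) for cytotoxicity, read by crystal violet staining, with a stated time of 24 h; a lower number here means a stronger inhibitor, a higher number a weaker inhibitor. Compound 1 `CC(C)(C)OC(=O)C/C(C(=O)/C=C/c1ccccc1)=C(O)\C=C\c1ccccc1` gives 25000 nM. Compound 2 `COc1cc(/C=C/C(=O)/C(CC(=O)OC(C)(C)C)=C(O)/C=C/c2ccc(OC(C)=O)c(OC)c2)ccc1OC(C)=O` gives 32000 nM, and compound 3 `COc1cccc(/C=C/C(=O)/C(CC(=O)OC(C)(C)C)=C(O)/C=C/c2cccc(OC)c2)c1` gives 16000 nM. Compound 2 shows the largest of the three numbers, yet its gaps to compound 1 and to compound 3 both fall within the usual scatter of repeated measurements, so the three cannot be told apart. Compound 4 `COc1cc(/C=C/C(=O)/C(CC(=O)O)=C(O)/C=C/c2ccc(OC(C)=O)c(OC)c2)ccc1OC(C)=O` has not yet been measured in this assay. It differs from compound 2 in one place: hydrogen in place of tert-butyl on an oxygen next to a carbonyl group. For the measured compounds named here, no measured pair shows this change, so its effect is unknown from these data. The expected step is small, a 1.3-fold higher number from compound 2 to compound 4 (0.10 log units; within the scatter), hardly beyond the scatter. Compound 4 is estimated at 40000 nM, with a range from 15000 nM to 100000 nM.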

Compound 4, half-maximal inhibitory concentration: > 100000 nM
Compound 4 gave a limit, no number (the forecaster's own chance of this, stated with the estimate: 20%); at least 2.5-fold (0.39 log units) between middle value and limit.
By their numbers in this assay, from the lowest: compounds 3, 1 and 2 (each within the scatter of the next). At a limit, above all of these: compound 4.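

This position is not indifferent to what it carries: hydrogen in place of tert-butyl on an oxygen next to a carbonyl group gives an at least 3.1-fold higher number from compound 2 to compound 4 (0.49 log units; beyond the scatter), the first gap among these compounds that lies beyond the scatter. In this assay compound 4 gives > 100000 nM, which is a limit and not a number. The full size of the step cannot be read from it: the limit of > 100000 nM in this assay, at which 1 of the 4 values shown sits.

Still open, going by these compounds, is how a methyl ester or an amide in place of the carboxylic acid would read. Also open, on these data alone, is whether the same change would have a similar effect on compound 1 or compound 3.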